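A few compounds are considered here, and "the series" means these few. Any claim that something is new, unique, unknown or untested is made for them only; others in the source may bear on it.

Compound 1 `COC1Cc2c(cnn2-c2ccccc2)C2(CCN(CCCCc3ccccc3)CC2)O1` gives 3.2 nM in an assay for displacement of a labelled ligand from Sigma non-opioid intracellular receptor 1 (Cavia porcellus), read by scintillation counting, with a stated time of 180 min; on this read-out higher numbers stand for weaker inhibition and lower numbers for stronger inhibition. Compound 2 `CCCCN1CCC2(CC1)OC(OC)Cc1c2cnn1-c1ccccc1` differs from compound 1 by hydrogen in place of phenyl on a saturated chain carbon, four bonds along the chain from an amine nitrogen in a ring; in this assay compound 2 gives 8 nM, and the step of a 2.5-fold higher number from compound 1 to compound 2 (0.40 log units; beyond the scatter). Compound 3 `COC1Cc2c(cnn2C)C2(CCN(CCCc3ccccc3)CC2)O1` gives 93 nM, the highest number among the three measured, with compound 2 the nearest. The difference between the core of compound 1 and the core of compound 3 is not broken down here.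

Compound 4 `CCCN1CCC2(CC1)OC(OC)Cc1c2cnn1C`, not yet measured, differs from compound 3 by hydrogen in place of phenyl on a saturated chain carbon, three bonds along the chain from an amine nitrogen in a ring. This is the same kind of change as from compound 1 to compound 2, though there the place was four bonds along the chain from the amine nitrogen and here it is three. For compound 4 a step of about a 3.0-fold higher number from compound 3 to compound 4 (0.48 log units; beyond the scatter) is expected in this assay, resting on the step of a 2.5-fold higher number from compound 1 to compound 2 (0.40 log units; beyond the scatter) and on compound 3 giving 93 nM. Compound 4 is thus estimated at 280 nM, with a plausible range of 120 nM to 700 nM.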

Compound 4, inhibition constant: > 1000 nM
Compound 4 ended at the assay's limit; the forecaster's own chance of this, stated with the estimate: 5%; at least 3.5-fold (0.55 log units) between middle value and limit.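

In this assay compound 4 gives > 1000 nM, which is a limit of the assay and not a number. The change does not carry over between these cores at one size, since the new step, an at least 10-fold higher number from compound 3 to compound 4 (1.03 log units; beyond the scatter), stands apart from the earlier one: the same change on two cores in this assay, a 2.5-fold higher number (0.40 log units; beyond the scatter) from compound 1 to compound 2 and an at least 10-fold higher number (1.03 log units; beyond the scatter) from compound 3 to compound 4, at least 4.3-fold (0.63 log units) apart, beyond the scatter of two such steps This does not give the true size of the new step, nor does it separate the core from the place of the change, which lies four bonds along the chain in the first pair and three in the second; the limit reads: the limit of > 1000 nM in this assay, at which 1 of the 4 values shown sits.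

Still open, from the compounds shown here alone, is whether the gap follows the core or the chain, which would need the same chain on both cores. Also open, going by these compounds, is how a cyclohexyl or pyridyl group in place of phenyl would behave on either core.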